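The source may report more compounds than this note shows. Statements on the series, on what has been measured and on what is new or still open speak of the compounds shown alone.

Among the compounds with values here, in a functional assay on CHO cells for agonist activity at Free fatty acid receptor 1 (Homo sapiens), read by FLIPR and calcium flux (on this read-out higher numbers stand for an effect only at larger amounts of compound and lower numbers for an effect already at smaller amounts), compound 2 `N#Cc1ccccc1-c1cccc(COc2ccc(S(=O)(=O)CC(=O)O)cc2)c1` gives 457 nM, the higher of the two numbers measured so far; its nearest neighbour, compound 1 `O=C(O)CS(=O)(=O)c1ccc(OCc2cccc(-c3ccccc3C(F)(F)F)c2)cc1`, gives 52.5 nM. Within the data shown here, the one measured step, an 8.7-fold higher number from compound 1 to compound 2 (0.94 log units; beyond the scatter), bears directly on the change to compound 3 `CCOc1ccc(-c2cccc(COc3ccc(S(=O)(=O)CC(=O)O)cc3)c2)c(Cl)c1`, which is 2-chloro-4-ethoxyphenyl in place of 2-cyanophenyl on an aromatic carbon. Since replacing trifluoromethyl by cyano raised the number by that amount, restoring a halogen at the same position with an added ethoxy group is expected to reverse the step, estimated as a 15-fold lower number from compound 2 to compound 3 (1.18 log units; beyond the scatter). For compound 3 the expected value in this assay is 30 nM, ranging from 8 nM to 120 nM.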

Compound 3, half-maximal effective concentration in the Free fatty acid receptor 1 assay: 51.3 nM
Beside the measured number, compound 3's estimate is 1.7-fold (0.23 log units) below it; the measured number falls inside the stated range.
By their numbers in the Free fatty acid receptor 1 assay, from the lowest: compounds 3 and 1 (each within the scatter of the next); then compound 2.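

In the Free fatty acid receptor 1 assay the 2-chloro-4-ethoxyphenyl group gives an 8.9-fold lower number from compound 2 to compound 3 (0.95 log units; beyond the scatter), so the higher number seen with 2-cyanophenyl does not persist with this group at this position. Against 2-(trifluoromethyl)phenyl the same group gives a 1.0-fold lower number from compound 1 to compound 3 (0.01 log units; within the scatter), which shows that this aromatic carbon carries the larger substituent with no difference beyond the scatter, and leaves compound 2 as the one apart among the three. No evidence given here explains this.

Within the data shown here, in a physicochemical assay for lipophilicity, using the shake flask method, in phosphate buffer, measured as octanol-water partition, with a stated time of 24 h, at pH 7.4, tested at 100 uM (on this read-out lower numbers stand for lower lipophilicity and higher numbers for higher lipophilicity), compound 3 gives 3.12 as a lone value and compound 2 gives "not determined" (no result reported), so no step to compound 2 can be read. Whether the chlorine or the ethoxy group accounts for the step stays open, as does the effect of an amine on this ring.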